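Replacing the imidazolyl group with an anilino group

A few compounds are considered here, and "the series" means these few. Any claim that something is new, unique, unknown or untested is made for them only; others in the source may bear on it.

Measured compounds:
compound 1 `Cc1cc(Br)c(S(C)(=O)=O)cc1C(=O)N=C(N)N` gives 12 nM
compound 2 `Cc1cc(N2CCCC2)c(S(C)(=O)=O)cc1C(=O)N=C(N)N` gives 11 nM
compound 3 `Cc1cc(-n2ccnc2C)c(S(C)(=O)=O)cc1C(=O)N=C(N)N` gives 29 nM

All three compounds were tested in a functional assay for inhibition of sodium/hydrogen exchanger (Oryctolagus cuniculus); a lower number here means a stronger inhibitor, a higher number a weaker inhibitor. Compound 3 stands at the top of the three numbers, so it is the weakest inhibitor among them: from compound 1 to compound 3 the number rose a 2.4-fold higher number from compound 1 to compound 3 (0.38 log units; beyond the scatter), and from compound 2 to compound 3 it rose a 2.6-fold higher number from compound 2 to compound 3 (0.42 log units; beyond the scatter). From compound 1 to compound 2 the change was a 1.1-fold lower number from compound 1 to compound 2 (0.04 log units; within the scatter), so these two cannot be told apart.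

Compound 4 `Cc1cc(Nc2cccc(Cl)c2)c(S(C)(=O)=O)cc1C(=O)N=C(N)N` has not been measured. It differs from compound 3 in one place: (3-chlorophenyl)amino in place of 2-methyl-1H-imidazol-1-yl on an aromatic carbon. All three measured steps concern this very position, and they show that exchanging the group there has moved the number only by modest amounts, with the imidazolyl group giving the highest value. For the measured compounds named here, no measured step involves an anilino group, so the direction for compound 4 rests on the observation that the two other groups tried here gave lower numbers than compound 3.

Compound 4 is therefore expected to give a modestly lower number than compound 3, a step of a 1.9-fold lower number from compound 3 to compound 4 (0.29 log units; within the scatter), estimated at 15 nM with a range from 5 nM to 50 nM.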

Compound 4, half-maximal inhibitory concentration: 33 nM
Estimate against measurement, compound 4: 2.2-fold (0.34 log units) below; measured number inside the range.
By their numbers in this assay, from the lowest: compounds 2 and 1 (each within the scatter of the next); then compounds 3 and 4 (each within the scatter of the next).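

In this assay, the (3-chlorophenyl)amino group brings a six-membered aromatic ring of carbon only and a hydrogen-bond donor to this position, yet the number cannot be told apart from that of the 2-methyl-1H-imidazol-1-yl group it replaces (a 1.1-fold higher number from compound 3 to compound 4 (0.06 log units; within the scatter)). Compound 4 does stand apart from the bromo and pyrrolidin-1-yl compounds, by modest steps (a 2.8-fold higher number from compound 1 to compound 4 (0.44 log units; beyond the scatter) and a 3.0-fold higher number from compound 2 to compound 4 (0.48 log units; beyond the scatter)). For the compounds shown here, the four compounds therefore fall into two pairs, with both groups that carry an aromatic ring in the pair with the higher numbers, and no exchange at this position so far goes beyond a modest step.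

Nothing available explains this split into two pairs. Still open, going by these compounds, is whether the chlorine on the anilino ring contributes at all, and whether an unsubstituted anilino group, a methoxy group or a carboxylic acid at this position would join the lower pair, the higher pair or neither.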